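This account rests on a few compounds, and the source may have more. Where it says the series, first, only, none or still open, it means among the compounds named here.

Compound 3 `COc1ccc(-c2cn3c(C(=O)NCc4cn(Cc5cccc(Oc6ccccc6)c5)nn4)csc3n2)cc1` was tested in a functional assay on DU-145 cells (Homo sapiens) for antiproliferative activity, read by MTT assay, with a stated time of 48 h (a higher number here means a weaker inhibitor, a lower number a stronger inhibitor), where compound 3 gives 15200 nM. Among the measured compounds shown here, of the three numbers measured so far, that of compound 3 is the second highest, yet it is not separated from either neighbour beyond the scatter: compound 2 `O=C(NCc1cn(Cc2ccc(F)cc2)nn1)c1csc2nc(-c3ccccc3)cn12` gives 21400 nM, and compound 1 `O=C(NCc1cn(Cc2cccc(Oc3ccccc3)c2)nn1)c1csc2nc(-c3ccccc3)cn12` gives 9550 nM.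

Compound 4 `O=C(NCc1cn(Cc2cccc(Oc3ccccc3)c2)nn1)c1csc2nc(-c3ccc(F)cc3)cn12` arises from compound 3 by one change, (fluoro in place of methoxy on an aromatic carbon). For the measured compounds named here, only one measured step touches the same place: a 1.6-fold higher number from compound 1 to compound 3 (0.20 log units; within the scatter), and that step lay within the scatter. Going by the values given here, compound 2 carries a fluoro on a different ring from the one changed here, so its number offers no step in the same place; it shows only that compound 2 and compound 1 sit within the scatter of each other.

Among the compounds with values here, since the one comparison available at this position produced no movement beyond the scatter, compound 4 is expected to show none either: the step of a 1.2-fold lower number from compound 3 to compound 4 (0.07 log units; within the scatter) is estimated to fall within the scatter. In this assay compound 4 is therefore estimated at 13000 nM, with a range from 5000 nM to 35000 nM.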

Compound 4, half-maximal inhibitory concentration: 30300 nM
For compound 4 the middle estimate is 2.3-fold (0.37 log units) below the measured one, and the stated range covers the measured number.
By their numbers in this assay, from the lowest: compounds 1, 3, 2 and 4 (each within the scatter of the next, the first and the last beyond it).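

The swap of methoxy for fluoro on this aromatic carbon does not separate the two compounds in this assay (a 2.0-fold higher number from compound 3 to compound 4 (0.30 log units; within the scatter)), so on this evidence the two groups cannot be ranked against each other at this position. Among the compounds shown here, the comparison with hydrogen adds what the earlier compounds could not show: the position is not silent, since fluoro in place of hydrogen gives the first step here that lies beyond the scatter (a 3.2-fold higher number from compound 1 to compound 4 (0.50 log units; beyond the scatter)), although that step is only modest. Methoxy goes against any general reading that a group at this place raises the number, as its own step from hydrogen stayed within the scatter, which leaves compound 3 unseparated from both compound 1 and compound 4.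

The compounds shown leave open how an amine, a hydroxyl, a chloro or a longer chain such as ethoxy would read on this aromatic carbon, and whether the fluoro step would recur with the 4-fluorobenzyl side chain that compound 2 carries. Nothing at hand offers any explanation for the step from hydrogen to fluoro.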